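A few compounds are considered here, and "the series" means these few. Any claim that something is new, unique, unknown or untested is made for them only; others in the source may bear on it.

Measured in a functional assay on HT-29 cells (Homo sapiens) for inhibition, read by CCK-8 assay, with a stated time of 24 h; a lower number here means a stronger inhibitor, a higher number a weaker inhibitor:
- compound 1 `Cc1ccc(-n2cc(-c3ccc(/C=C4\C(=O)Nc5ccc(F)cc54)cc3)nn2)cc1`: 3980 nM
- compound 2 `O=C1Nc2ccc(F)cc2/C1=C/c1ccc(-c2cn(-c3cccc(F)c3)nn2)cc1`: > 12900 nM (a limit, not a number)
- compound 3 `O=C1Nc2ccc(F)cc2/C1=C/c1ccc(-c2cn(-c3ccccc3Cl)nn2)cc1`: 5950 nM

Within the data shown here, only two of these values are exact numbers, and they cannot be told apart: a 1.5-fold higher number from compound 1 to compound 3 (0.17 log units; within the scatter). Among the measured compounds shown here, compound 3 therefore stands level with the only other exact number. A gap beyond the scatter appears only against the limit: an at least 2.1-fold lower number from compound 2 to compound 3 (0.33 log units; beyond the scatter).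

Compound 4 `O=C1Nc2ccc(F)cc2/C1=C/c1ccc(-c2cn(-c3cccc(Cl)c3)nn2)cc1` has the same atoms as compound 3, joined differently: 3-chlorophenyl in place of 2-chlorophenyl on an aromatic nitrogen. In words, it carries 3-chlorophenyl in place of 2-chlorophenyl on an aromatic nitrogen.

For the measured compounds named here, no measured step makes exactly this change, so the nearest guide is compound 2, which has 3-fluorophenyl on that nitrogen. Two steps involving compound 2 bear on the question: an at least 3.2-fold higher number from compound 1 to compound 2 (0.51 log units; beyond the scatter), and the gap to compound 3 given above. Both point towards a higher number, but they rest on this single compound, and its halogen is fluorine rather than chlorine. A modest rise in the number, meaning a weaker inhibitor, is therefore expected, though a result within the scatter would be no surprise.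

The estimated step is a 1.4-fold higher number from compound 3 to compound 4 (0.15 log units; within the scatter). For compound 4 the expected value is 8500 nM, with an estimated range of 3500 nM to 20000 nM.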

Compound 4, half-maximal inhibitory concentration: 10500 nM
Beside the measured number, compound 4's estimate is 1.2-fold (0.09 log units) below it, and the stated range covers the measured number.
By their numbers in this assay, from the lowest: compounds 1, 3 and 4 (each within the scatter of the next, the first and the last beyond it). At a limit, above all of these: compound 2.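

Compound 4 carries 3-chlorophenyl on the aromatic nitrogen in place of 2-chlorophenyl: a 1.8-fold higher number from compound 3 to compound 4 (0.25 log units; within the scatter). In this assay these two compounds therefore cannot be told apart. The comparison with the 4-methylphenyl group does show something new. Compound 3 stayed level with compound 1, while 3-chlorophenyl opens a gap: a 2.6-fold higher number from compound 1 to compound 4 (0.42 log units; beyond the scatter). These two results sit together only loosely: the two chlorophenyl compounds cannot themselves be separated. Chloro in place of fluoro gives an at least 1.2-fold lower number from compound 2 to compound 4 (0.08 log units; that floor lies within the scatter), so nothing can be said about chloro against fluoro. Compound 2 carries a limit and not a number: the limit of > 12900 nM in this assay, at which 1 of the 4 values shown sits.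

The phenyl group on this nitrogen is shown here only with a methyl, a fluoro or a chloro group, so how a methoxy group, an amine or a carboxylic acid would behave at this place remains open. Going by these compounds, whether the gap between 3-chlorophenyl and 4-methylphenyl would also appear in cells other than these remains open too.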